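Bridged amide substituent swapped for oxygen-bridged analogue

A few compounds are considered here, and "the series" means these few. Any claim that something is new, unique, unknown or untested is made for them only; others in the source may bear on it.

Measured compounds: compound 1 `O=C(NC1CCCCC1)NS(=O)(=O)N1CCC(CCNC(=O)c2cccc3c2OCCO3)CC1`, 42%; compound 2 `CCCNC(=O)NS(=O)(=O)N1CCC(CCNC(=O)c2cccc3c2OCCO3)CC1`, 25%; compound 3 `O=C(NC[C@@H]1C[C@@H]2C=C[C@@H]1C2)NS(=O)(=O)N1CCC(CCNC(=O)c2cccc3c2OCCO3)CC1`, 40%.

The three compounds share one core and differ only in the group on the amide-type nitrogen of the sulfonylurea arm. In a functional assay on the whole organism (blood) with Rattus norvegicus as the target, with stated times of 24 h and 1 h, at a dose of 15 mg/kg by the intraperitoneal route (on this read-out lower numbers stand for a weaker effect and higher numbers for a stronger effect at the one dose given), compound 3 gives 40%, the second highest of the three numbers. Its nearest neighbour is compound 1; the two lie within the scatter of each other, as the step of a number 2 percentage points lower from compound 1 to compound 3 (within the scatter) shows. The step of a number 15 percentage points higher from compound 2 to compound 3 (beyond the scatter) is the only one beyond the scatter that involves compound 3, and a number 17 percentage points lower from compound 1 to compound 2 (beyond the scatter) points the same way: the small open chain of compound 2 gives a weaker read-out than either ring-bearing group.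

Compound 4 `O=C(NC[C@@H]1C[C@@H]2CC[C@@H]1O2)NS(=O)(=O)N1CCC(CCNC(=O)c2cccc3c2OCCO3)CC1` keeps the bridged bicyclic shape of compound 3 and changes it as follows: a group of 7 heavy atoms (6 carbon, 1 oxygen; 2 five-membered non-aromatic rings with 1 hetero atom each) in place of a group of 7 heavy atoms (7 carbon; 2 five-membered non-aromatic rings of carbon only), on a saturated chain carbon bound to an amide-type nitrogen. Among the compounds with values here, no measured step covers an exchange of this kind; the two steps that touch compound 3 concern ring versus chain, not carbon versus oxygen within a bicycle. Since the two ring-bearing groups gave numbers within the scatter of each other, the expected step of a number 4 percentage points lower from compound 3 to compound 4 (within the scatter) is small, with a slight lean downward. Compound 4 is therefore estimated at 36%, within 22% to 50%.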

Compound 4, a percentage reported as activity, at one dose (the size of the read-out at that dose, not a potency): 13%
Compound 4: the middle estimate sits 23 percentage points above what was measured; measured number below the stated range.
By their numbers in this assay, from the lowest: compound 4; then compound 2; then compounds 3 and 1 (each within the scatter of the next).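

At the saturated chain carbon bound to an amide-type nitrogen, this assay proves sensitive to what the bicyclic group is made of, not only to whether a ring is present: with the same count of heavy atoms and the same ring count, the exchange in compound 4 still gives a clear drop (a number 27 percentage points lower from compound 3 to compound 4 (beyond the scatter)). The earlier compounds shown here placed both ring-bearing groups above the open chain, but compound 4 carries rings and goes against that pattern (a number 12 percentage points lower from compound 2 to compound 4 (beyond the scatter)), and it also lies well under the compound with the cyclohexyl group (a number 29 percentage points lower from compound 1 to compound 4 (beyond the scatter)). Nothing available here accounts for this drop.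

The step from compound 3 to compound 4 brings in the ring oxygen and removes the double bond at once, so the compounds shown do not tell which of the two goes with the lower number. A saturated all-carbon bicyclic group would separate the two, and a bicyclic group with an amine nitrogen in place of the oxygen would show whether the drop is particular to oxygen.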